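This account rests on a few compounds, and the source may have more. Where it says the series, first, only, none or still open, it means among the compounds named here.

The measured compounds are compound 1 `N#Cc1cc2c(nc1N1CCC(C(=O)NS(=O)(=O)Cc3ccccc3)C1)COC2=O`, compound 2 `CC1OC(=O)c2cc(C#N)c(N3CCC(C(=O)NS(=O)(=O)Cc4ccccc4)C3)nc21` and compound 3 `N#Cc1cc2c(nc1N1CCC(C(=O)NS(=O)(=O)c3ccc(Cl)s3)CC1)COC2=O`.

In a functional assay (Platelet, plasma) for inhibition, with Homo sapiens as the target (on this read-out lower numbers stand for stronger inhibition and higher numbers for weaker inhibition), compound 1 gives > 300000 nM, which is a limit of the assay and not a number. In this assay compound 2 likewise gives > 300000 nM, again a limit. In this assay compound 3 gives 4470 nM. The change methyl in place of hydrogen on a saturated ring carbon produced a step that the two limits leave unreadable from compound 1 to compound 2, and its size stays unreadable because of the limit of > 300000 nM in this assay, at which 2 of the 3 values shown sit. The difference between the core of compound 1 and the core of compound 3 is not broken down here. Compound 4 `CC1OC(=O)c2cc(C#N)c(N3CCC(C(=O)NS(=O)(=O)c4ccc(Cl)s4)CC3)nc21` differs from compound 3 by the same change, (methyl in place of hydrogen on a saturated ring carbon). Among the measured compounds shown here, since the one measured instance of this change yields no readable size, compound 4 is expected to sit close to compound 3, with an estimated step of a 1.0-fold higher number from compound 3 to compound 4 (0.00 log units; within the scatter). Compound 4 is therefore estimated at 4500 nM, expected between 1500 nM and 15000 nM.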

Compound 4, half-maximal inhibitory concentration: > 300000 nM
Compound 4 ended at the assay's limit; the forecaster's own chance of this, stated with the estimate: 5%; middle value at least 66-fold (1.82 log units) away from the limit.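

The change of methyl in place of hydrogen on a saturated ring carbon produces an at least 67-fold higher number from compound 3 to compound 4 (1.82 log units; beyond the scatter) in this assay, so on the core of compound 3 it is far from neutral. In this assay compound 4 gives > 300000 nM, which is a limit of the assay and not a number. The step from compound 1 to compound 2 cannot be read, so the size is known on one core only and the series does not show whether it carries from one core to another: the limit of > 300000 nM in this assay, at which 3 of the 4 values shown sit.

Left open is whether ethyl or hydroxymethyl on that same ring carbon would keep the value of compound 3. Also open, going by these compounds, is how the methyl change behaves on any further core.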